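Extending the aryl group on the saturated ring carbon

The source may report more compounds than this note shows. Statements on the series, on what has been measured and on what is new or still open speak of the compounds shown alone.

Of the compounds shown here, three sharing one core have so far been tested in a functional assay on WM 266-4 cells (Homo sapiens) for antiproliferative activity, read by MTT assay, with a stated time of 24 h; a lower number here means a stronger inhibitor of growth, a higher number a weaker inhibitor of growth. Compound 1 `c1ccc(C2CC(c3ccc4c(c3)OCCO4)=NN2c2ccccc2)cc1` gives 22400 nM. Compound 2 `Ic1ccc(C2CC(c3ccc4c(c3)OCCO4)=NN2c2ccccc2)cc1` gives 3470 nM, and compound 3 `Cc1ccc(C2CC(c3ccc4c(c3)OCCO4)=NN2c2ccccc2)cc1` gives 2530 nM. Compound 3 therefore holds the lowest of the three numbers, although its separation from compound 2 is within the scatter, while its separation from compound 1 is beyond it.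

Compound 4 `c1ccc(N2N=C(c3ccc4c(c3)OCCO4)CC2c2ccc3ccccc3c2)cc1` has not yet been measured. It differs from compound 3 by naphthalen-2-yl in place of 4-methylphenyl on a saturated ring carbon.

Among the compounds with values here, two measured steps bear on this change, both enlarging the same aryl group from hydrogen: an 8.9-fold lower number from compound 1 to compound 3 (0.95 log units; beyond the scatter) and a 6.5-fold lower number from compound 1 to compound 2 (0.81 log units; beyond the scatter). The third step, a 1.4-fold lower number from compound 2 to compound 3 (0.14 log units; within the scatter), shows that swapping one such substituent for another changes little. A naphthalen-2-yl extends that ring further still, so a modest further lowering, or none beyond the scatter, is expected, a 1.7-fold lower number from compound 3 to compound 4 (0.23 log units; within the scatter). Compound 4 is estimated at 1500 nM, within a range of 500 nM to 5000 nM.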

Compound 4, concentration for 50% growth inhibition: 13900 nM
Estimate against measurement, compound 4: 9.3-fold (0.97 log units) below, and the stated range ends below it.
By their numbers in this assay, from the lowest: compounds 3 and 2 (each within the scatter of the next); then compounds 4 and 1 (each within the scatter of the next).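

In this assay, enlarging the aryl group on the saturated ring carbon does not keep lowering the number: naphthalen-2-yl gives a 5.5-fold higher number from compound 3 to compound 4 (0.74 log units; beyond the scatter) and a 4.0-fold higher number from compound 2 to compound 4 (0.60 log units; beyond the scatter), so the position that accepts 4-methylphenyl and 4-iodophenyl loses that gain with a second aromatic ring. Against plain phenyl, naphthalen-2-yl gives a 1.6-fold lower number from compound 1 to compound 4 (0.21 log units; within the scatter), which places compound 4 level with compound 1 rather than with the two substituted compounds. Size alone therefore does not order these four compounds, and nothing available here accounts for the reversal.

The compounds shown leave open whether an ethyl or a longer alkyl chain in place of the methyl would stay with compound 3 or fall back with compound 4. They also leave open how naphthalen-1-yl, or an amine or a carboxylic acid on the phenyl ring, would read at this position.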